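The source may report more compounds than this note shows. Statements on the series, on what has been measured and on what is new or still open speak of the compounds shown alone.

Measured compounds:
compound 1 `CCCN(c1ccccc1)S(=O)(=O)c1ccc(N2CCCC2=O)cc1` — > 5000 nM
compound 2 `CN1CCN(S(=O)(=O)c2ccc(N3CCCC3=O)cc2)c2ccccc21` — 13 nM

Within the data shown here, in a functional assay on MDA-MB-231 cells (Homo sapiens) for antiproliferative activity, read by fluorescence and SYBR Green assay, with a stated time of 24 h (on this read-out higher numbers stand for weaker inhibition and lower numbers for stronger inhibition), compound 2 gives 13 nM, the only numeric value among the two measured compounds. Compound 1 gives > 5000 nM, a limit of the assay rather than a number (the limit of > 5000 nM in this assay, at which 1 of the 2 values shown sits). Compound 3 `CN1CCN(S(=O)(=O)c2ccc(N3CCCC3)cc2)c2ccccc21` differs from compound 2 by pyrrolidin-1-yl in place of 2-oxopyrrolidin-1-yl on an aromatic carbon. Among the measured compounds shown here, no measured step covers this change. The expectation in this assay is a loss beyond the scatter, a 9.2-fold higher number from compound 2 to compound 3 (0.97 log units; beyond the scatter). Compound 3 is estimated at 120 nM, with a range from 15 nM to 1500 nM.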

Compound 3, half-maximal inhibitory concentration: 16 nM
The estimate for compound 3 lay 7.5-fold (0.88 log units) above the measured number, within the range that was stated.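

In this assay, pyrrolidin-1-yl and 2-oxopyrrolidin-1-yl on the aromatic carbon para to a large group stand within the scatter of each other: a 1.2-fold higher number from compound 2 to compound 3 (0.09 log units; within the scatter). For this pair on the shared core, the carbonyl of the five-membered ring is therefore not required to keep the value in the low range set by compound 2. Nothing shown here bears on the reason for this result.

On these data alone, whether this position accepts other groups remains open, for example morpholine, piperidine or an open-chain dimethylamino group. A carboxylic acid at this place is equally untested in the compounds shown.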